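The source may hold more compounds than are shown below. What is called first, only, known or untested is meant among the compounds shown, and "the series" means these compounds.

Compound 3 `CCCCCC(O)C1=CC(=O)c2c(OC)ccc(OC)c2C1=O`: 0.378 ug/mL in a functional assay on L1210 cells (Mus musculus) for cytotoxicity; on this read-out higher numbers stand for an effect only at larger amounts of compound and lower numbers for an effect already at smaller amounts.
Compound 1 `CCCC(O)C1=CC(=O)c2c(OC)ccc(OC)c2C1=O`: 0.409 ug/mL.
Compound 2 `CCC(O)C1=CC(=O)c2c(OC)ccc(OC)c2C1=O`: 0.516 ug/mL.

All three share one core and differ only in the length of the chain on the saturated chain carbon that carries the oxygen. Compound 3 shows the smallest number of the three, yet every gap is within the scatter: a 1.1-fold lower number from compound 1 to compound 3 (0.03 log units; within the scatter), a 1.4-fold lower number from compound 2 to compound 3 (0.14 log units; within the scatter), and a 1.3-fold higher number from compound 1 to compound 2 (0.10 log units; within the scatter). Compound 4 `COc1ccc(OC)c2c1C(=O)C=C(CO)C2=O` takes the shortening to its end: hydrogen in place of pentyl on a saturated chain carbon bound to a double-bonded ring carbon and an oxygen on a saturated carbon. Within the data shown here, no measured step removes the whole chain, so the three chain-length steps bear on it only loosely; they suggest little dependence on chain length. The expected step is a 1.6-fold higher number from compound 3 to compound 4 (0.20 log units; within the scatter), none beyond the scatter, with wide uncertainty. Compound 4 is estimated at 0.6 ug/mL, between 0.25 ug/mL and 1.5 ug/mL.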

Compound 4, concentration for half-maximal effect: 0.524 ug/mL
Compound 4: middle estimate off by 1.1-fold (0.06 log units), on the high side; low and high end bracket the measured number.
By their numbers in this assay, from the lowest: compounds 3, 1, 2 and 4 (each within the scatter of the next).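

In this assay, even replacing the whole pentyl with hydrogen stays within the scatter, with a 1.4-fold higher number from compound 3 to compound 4 (0.14 log units; within the scatter), alongside a 1.0-fold higher number from compound 2 to compound 4 (0.01 log units; within the scatter) and a 1.3-fold higher number from compound 1 to compound 4 (0.11 log units; within the scatter). From hydroxymethyl up to 1-hydroxyhexyl, these numbers therefore show no dependence on chain length at this position. The same chain change also reads alike when it starts from a different compound: the same change on two cores in this assay, a 1.1-fold lower number (0.03 log units; within the scatter) from compound 1 to compound 3 and a 1.0-fold lower number (0.01 log units; within the scatter) from compound 4 to compound 2, 1.1-fold (0.03 log units) apart, within the scatter of two such steps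

From the compounds shown here alone, whether an amine, a carboxylic acid or a chain longer than pentyl on this carbon would move the number beyond the scatter stays open. Going by these compounds, all four compounds keep the oxygen on the saturated carbon, so its own contribution also stays open.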